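A Larger Ester-Bearing Group Replaces Hydroxymethyl

The source may report more compounds than this note shows. Statements on the series, on what has been measured and on what is new or still open speak of the compounds shown alone.

- Compound 1 `C=C[C@@](C)(/C=C/c1ccc(O)cc1)CCC=O`: > 36600 nM
- Compound 2 `C=C[C@@](C)(/C=C/c1ccc(O)cc1)CC/C=C/C(=O)OCc1ccccc1`: > 36600 nM
- Compound 3 `C=C[C@@](C)(/C=C/c1ccc(O)c(CO)c1)CCC=C(C)C`: > 36600 nM

These results come from an ADME assay on HEK293 cells (Homo sapiens) for cytotoxicity, with a stated time of 72 h; a higher number here means that more compound is needed for the effect, a lower number that less compound is needed. None of the three compounds gives an exact number, and the shared result is the limit of > 36600 nM in this assay, at which 3 of the 3 values shown sit. Compound 3 gives > 36600 nM, which is a limit and not a number.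

In compound 4 `C=C[C@@](C)(/C=C/c1ccc(O)c(/C=C(\C)C(=O)OCC)c1)CCC=C(C)C`, 2-(ethoxycarbonyl)prop-1-en-1-yl stands in place of hydroxymethyl on an aromatic carbon, ortho to a hydroxy group: 2-(ethoxycarbonyl)prop-1-en-1-yl in place of hydroxymethyl on an aromatic carbon. Among the compounds with values here, no measured pair of compounds shows what a change at this place does in this assay. The expectation therefore starts from compound 3 at > 36600 nM, and a reading at the limit would not be surprising. The expected step of an at least 1.2-fold lower number from compound 3 to compound 4 (0.08 log units; that floor lies within the scatter) is small, towards slightly less compound needed, and is not expected to exceed the usual scatter. For compound 4 the estimate is 30000 nM, with an expected range from 11000 nM to 40000 nM.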

Compound 4, half-maximal effective concentration: > 36600 nM
Compound 4: a limit, no number; the forecaster's own chance of this, stated with the estimate: 70%; middle value at least 1.2-fold (0.08 log units) from the limit.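

No step can be read from compound 3 to compound 4 in this assay, because neither gives a number, only a limit: the limit of > 36600 nM in this assay, at which 4 of the 4 values shown sit.
The compounds shown leave open whether 2-(ethoxycarbonyl)prop-1-en-1-yl in place of hydroxymethyl changes the amount of compound needed for the effect at all.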